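The source may report more compounds than this note shows. Statements on the series, on what has been measured and on what is new or still open speak of the compounds shown alone.

Compound 1 `NS(=O)(=O)c1ccc(C(=O)N/N=C(/CS(=O)(=O)c2ccccc2)c2ccc(Cl)cc2)cc1`: 57000 nM
Compound 2 `NS(=O)(=O)c1ccc(C(=O)N/N=C(/CS(=O)(=O)c2ccccc2)c2ccc(F)cc2)cc1`: 620 nM

Within the data shown here, in a functional assay on MCF7 cells (Homo sapiens) for antiproliferative activity, read by MTT assay (on this read-out higher numbers stand for weaker inhibition and lower numbers for stronger inhibition), compound 1 holds the higher of the two numbers, and compound 2 is its only neighbour. Compound 3 `C/C(=N/NC(=O)c1ccc(S(N)(=O)=O)cc1)c1ccc(Cl)cc1` keeps the chloro group of compound 1 and changes elsewhere: hydrogen in place of phenylsulfonyl on a saturated chain carbon bound to a carbon with a double bond to nitrogen. In plain terms, this is hydrogen in place of phenylsulfonyl on a saturated chain carbon bound to a carbon with a double bond to nitrogen.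

Among the measured compounds shown here, the one measured step, a 92-fold lower number from compound 1 to compound 2 (1.96 log units; beyond the scatter), is large but lies at the halogen, so it bears only indirectly. It shows that this series can move far in this assay on a single change. For the measured compounds named here, no measured step covers the loss of phenylsulfonyl, so the direction is poorly supported. With compound 1 at 57000 nM, a modest move towards a lower number is expected, though little change remains possible. The expected shift is a 2.9-fold lower number from compound 1 to compound 3 (0.45 log units; beyond the scatter), with wide uncertainty. For compound 3 the estimated value is 20000 nM, with an expected range from 3000 nM to 100000 nM.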

Compound 3, half-maximal inhibitory concentration: 3750 nM
Compound 3: the middle estimate sits 5.3-fold (0.73 log units) above what was measured; the measured number falls inside the stated range.
By their numbers in this assay, from the lowest: compound 2; then compound 3; then compound 1.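

In this assay, the change from (phenylsulfonyl)methyl to methyl, with the chloro group held constant, gives a 15-fold lower number from compound 1 to compound 3 (1.18 log units; beyond the scatter). This shows that the saturated chain carbon bound to a carbon with a double bond to nitrogen is a second place where a single change moves the number strongly, alongside the halogen, where the step is a 92-fold lower number from compound 1 to compound 2 (1.96 log units; beyond the scatter); both steps start from compound 1, both are large, and both lead to a lower number. The phenylsulfonyl group is therefore not required for activity in this assay, since compound 3 lacks it and still has the lower number of the pair, but nothing measured here gives a reason for the step.

Still open, going by these compounds, is whether the halogen step keeps its direction and size when methyl stands in place of (phenylsulfonyl)methyl, as the fluoro and chloro pair is known only with phenylsulfonyl present. Also open, on these data alone, is how the number responds to other groups on the same saturated chain carbon, such as a longer alkyl chain, an amine or a carboxylic acid, and whether any of these would fall nearer compound 3 or compound 1.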